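The source may hold more compounds than are shown below. What is called first, only, known or untested is meant among the compounds shown, and "the series" means these compounds.

Measured so far in an ADME assay on cells (Macrophage, Mus musculus) for cytotoxicity, read by resazurin assay, with a stated time of 3 days; on this read-out lower numbers stand for stronger inhibition and higher numbers for weaker inhibition:
compound 1 `O=C(Nc1cc(C(F)(F)F)cc(C(F)(F)F)c1)c1cc(I)ccc1O` at 5600 nM
compound 2 `O=C(Nc1ccc(C(F)(F)F)cc1)c1cc(Cl)ccc1O` at 2800 nM
compound 3 `O=C(Nc1ccc(C(F)(F)F)c(C(F)(F)F)c1)c1cc(Cl)ccc1O` at 4900 nM

Compound 2 gives 2800 nM and neither of the other two compounds lies beyond the scatter of it. Compound 4 `O=C(Nc1ccc(OC(F)(F)F)cc1)c1cc(Cl)ccc1O` differs from compound 2 on an aromatic carbon, para to a large group, with trifluoromethoxy in place of trifluoromethyl on an aromatic carbon and nothing else changed. Within the data shown here, the one measured step is a 1.8-fold higher number from compound 2 to compound 3 (0.24 log units; within the scatter) with trifluoromethyl in place of hydrogen on an aromatic carbon, a different change but the only guide available. No step beyond the scatter is therefore expected in this assay in either direction. The estimated step is a 1.1-fold higher number from compound 2 to compound 4 (0.03 log units; within the scatter) and fits that expectation. For compound 4 the estimated value is 3000 nM with an expected range from 1500 nM to 6000 nM on this basis.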

Compound 4, half-maximal inhibitory concentration: 7300 nM
For compound 4 the middle estimate is 2.4-fold (0.39 log units) below the measured one, and the stated range ends below it.
By their numbers in this assay, from the lowest: compounds 2, 3, 1 and 4 (each within the scatter of the next, the first and the last beyond it).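

In this assay, among these compounds, the place on an aromatic carbon, para to a large group, proves sensitive to the group it carries: trifluoromethoxy in place of trifluoromethyl gives a 2.6-fold higher number from compound 2 to compound 4 (0.42 log units; beyond the scatter), the first single change here to go beyond the scatter. The extra trifluoromethyl of the earlier step, a 1.8-fold higher number from compound 2 to compound 3 (0.24 log units; within the scatter), had stayed within it. Nothing at hand accounts for this step.

Going by these compounds, whether an amine, a nitrile or a longer alkoxy chain at this place would shift the number further remains open. So does whether the same exchange gives a similar step on a core carrying iodine in place of chlorine.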